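Hydroxy in Place of Chloro: Outlook for Compound 4

The compounds below may be only part of what the source reports. "The series", "measured", "known", "first", "only" and "open" are said of these compounds alone.

In a functional assay on COLO 205 cells (Homo sapiens) for cytotoxicity, read by MTT assay, with a stated time of 48 h (on this read-out lower numbers stand for stronger inhibition and higher numbers for weaker inhibition), the three measured compounds stand as follows.
Compound 1 `Fc1cccc(-c2nc(Nc3ccccc3)c3ccccc3n2)c1` gives > 50000 nM.
Compound 2 `Fc1ccc(Nc2nc(-c3cccc(F)c3)nc3ccc(F)cc23)cc1` gives > 50000 nM.
Compound 3 `Fc1cccc(-c2nc(Nc3cccc(Cl)c3)c3cc(F)ccc3n2)c1` gives > 50000 nM.

Each of these values is a limit of the assay, not a number. Compound 3 thus stands at the limit of > 50000 nM in this assay, at which 3 of the 3 values shown sit, together with the other two. Within the data shown here, the only single-point step, a step that the two limits leave unreadable from compound 2 to compound 3, cannot be read.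

Compound 4 `Oc1cccc(Nc2nc(-c3cccc(F)c3)nc3ccc(F)cc23)c1` differs from compound 3 by hydroxy in place of chloro on an aromatic carbon. Among the measured compounds shown here, no measured step bears on this change, and the one available step gives no size or direction. The expected step of a number no higher from compound 3 to compound 4 (the limit leaves the size open) is therefore none beyond the scatter, with a limit again most likely. Compound 4 is estimated at 50000 nM, with a range from 10000 nM to 100000 nM.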

Compound 4, half-maximal inhibitory concentration: > 50000 nM
Compound 4 was reported as a limit; the forecaster's own chance of this, stated with the estimate: 75%; the middle value lies on the limit itself.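

Compound 4 gives > 50000 nM in this assay, a limit of the assay and not a number. Among these compounds, no step from compound 2 or compound 3 to compound 4 can be read. The compounds shown leave open whether any of these changes alters the read-out, as all sit at one limit: the limit of > 50000 nM in this assay, at which 4 of the 4 values shown sit.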